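From Imidazole to Pyrazole on the Propyl Chain

This account rests on a few compounds, and the source may have more. Where it says the series, first, only, none or still open, it means among the compounds named here.

Of the compounds shown here, two built on a shared core have so far been measured in a functional assay on Sf9 cells for antagonist activity at histamine H2 receptor (Homo sapiens), with stated times of 2 min and 20 min; a higher number here means a more potent compound, by a factor of ten per unit of this negative logarithm, a lower number a less potent compound. Compound 1 `N/C(=N\C(=O)CC(c1ccccc1)c1ccccc1)NCCCc1cccnc1` gives 6.14 in this assay. Compound 2 `N/C(=N\C(=O)CC(c1ccccc1)c1ccccc1)NCCCn1ccnc1` gives 5.82 in this assay, the lower of the two numbers, and the pair is separated by the step of a number 0.32 log units lower from compound 1 to compound 2 (beyond the scatter). Compound 3 `N/C(=N\C(=O)CC(c1ccccc1)c1ccccc1)NCCCc1cn[nH]c1` has not yet been measured. It differs from compound 2 by 1H-pyrazol-4-yl in place of 1H-imidazol-1-yl on a saturated chain carbon, three bonds along the chain from an amine nitrogen. Going by the values given here, no measured step concerns this particular exchange; the only step on record, a number 0.32 log units lower from compound 1 to compound 2 (beyond the scatter), replaces pyridin-3-yl with 1H-imidazol-1-yl at the same position and was modest in size. That step suggests that exchanging one small heteroaromatic ring for another at this position shifts this assay only modestly, so a small step is expected for a number 0.08 log units higher from compound 2 to compound 3 (within the scatter), with its direction not settled by the data in hand. Compound 3 is accordingly estimated at 5.9 in this assay, with a range from 5.4 to 6.4.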

Compound 3, negative logarithm of the antagonist equilibrium constant: 5.42
For compound 3 the middle estimate is 0.48 log units above the measured one, and the stated range covers the measured number.
By their numbers in this assay, from the lowest: compound 3; then compound 2; then compound 1.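

The exchange of 1H-imidazol-1-yl for 1H-pyrazol-4-yl keeps the atoms and the five-membered aromatic ring, and moves only how they are joined, yet in this assay it gives a number 0.40 log units lower from compound 2 to compound 3 (beyond the scatter) at this saturated chain carbon, so this position distinguishes between two rings of the same size and atom content. Together with the earlier step, the widest gap among the three compounds is a number 0.72 log units lower from compound 1 to compound 3 (beyond the scatter) and shows that exchanges among these rings can shift the number further than the single earlier step had indicated. Nothing measured here accounts for this fall, and it cannot be tied to the change in hydrogen-bond donors and acceptors or to any other feature.

The compounds shown leave open whether the point of attachment or the arrangement of the ring nitrogens carries the difference, a question that 1H-pyrazol-1-yl and 1H-imidazol-4-yl groups on the same propyl chain would address. They also leave open how a plain phenyl ring at this place, or an ethyl or butyl chain carrying pyridin-3-yl, would compare with these three.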